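Cyano for bromo on compound 3

A few compounds are considered here, and "the series" means these few. Any claim that something is new, unique, unknown or untested is made for them only; others in the source may bear on it.

In a functional assay on a cell-free system (plasma, Oryctolagus cuniculus) for inhibition, with stated times of 5 min, 1 min and 6 min (on this read-out lower numbers stand for stronger inhibition and higher numbers for weaker inhibition), compound 1 (`CCOC(=O)c1c(C)nc(-c2cccc(C#N)c2)n1OCc1cccc(F)c1`) gives 22400 nM, compound 2 (`CCOC(=O)c1c(C)nc(-c2cccc(C#N)c2)n1OCc1ccccc1Cl`) gives 8710 nM and compound 3 (`CCOC(=O)c1c(C)nc(-c2cccc(C#N)c2)n1OCc1ccc(Br)cc1`) gives 24600 nM. Compound 3 stands level with compound 1, as a 1.1-fold higher number from compound 1 to compound 3 (0.04 log units; within the scatter) shows, while a 2.8-fold higher number from compound 2 to compound 3 (0.45 log units; beyond the scatter) places it on the weaker side of compound 2. Compound 4 (`CCOC(=O)c1c(C)nc(-c2cccc(C#N)c2)n1OCc1ccc(C#N)cc1`) carries cyano in place of bromo on an aromatic carbon, para to a large group: cyano in place of bromo on an aromatic carbon. For the measured compounds named here, no measured step makes this exchange. The closest evidence is the changes on the phenyl ring, where a 2.6-fold lower number from compound 1 to compound 2 (0.41 log units; beyond the scatter) and the two steps above stay modest or smaller. In this assay, therefore, no step beyond the scatter is expected, and no direction is favoured. The expected value for compound 4 is 20000 nM, with an estimated range from 8000 nM to 50000 nM, which is an expected 1.2-fold lower number from compound 3 to compound 4 (0.09 log units; within the scatter).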

Compound 4, half-maximal inhibitory concentration: 4240 nM
Beside the measured number, compound 4's estimate is 4.7-fold (0.67 log units) above it; measured number outside the range, below it.
By their numbers in this assay, from the lowest: compound 4; then compound 2; then compounds 1 and 3 (each within the scatter of the next).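

At the place para to a large group, cyano in place of bromo gives a 5.8-fold lower number from compound 3 to compound 4 (0.76 log units; beyond the scatter) in this assay, so the group held there matters, which the earlier phenyl changes had not shown for this place. Compound 4 also stands apart from the two other compounds, with a 2.1-fold lower number from compound 2 to compound 4 (0.31 log units; beyond the scatter) and a 5.3-fold lower number from compound 1 to compound 4 (0.72 log units; beyond the scatter), and it has the lowest number of the four.

On these data alone, it remains open whether an amine, a carboxylic acid or a methoxy group at this place would match cyano, and whether cyano would act alike elsewhere on this ring. Nothing shown here explains the size of this step.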